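A Second Methyl on the Chain Before the Amide

The source may report more compounds than this note shows. Statements on the series, on what has been measured and on what is new or still open speak of the compounds shown alone.

In an assay on microsomes from intestine for inhibition of acyl-CoA:cholesterol acyltransferase (Oryctolagus cuniculus) (on this read-out higher numbers stand for weaker inhibition and lower numbers for stronger inhibition), compound 1, `CCCCCCCC/C=C/CCCCCCCC(=O)Nc1c(C)cccc1OC`, gives 20 nM. Compound 2, `CCCCCCCC/C=C/CCCCCCCC(=O)Nc1c(C)cccc1OCC`, carries methyl in place of hydrogen on a saturated chain carbon bound to an oxygen on an aromatic ring and in this assay gives 15 nM; the step is a 1.3-fold lower number from compound 1 to compound 2 (0.12 log units; within the scatter). Compound 3, `CCCCCCCC/C=C/CCCCCCC(C)C(=O)Nc1c(OC)cc(OC)cc1OC`, rests on another core, and the difference between the two cores is not broken down here; in this assay compound 3 gives 36 nM, a number within the scatter of compound 1 but beyond it against compound 2. Compound 4, `CCCCCCCC/C=C/CCCCCCC(C)(C)C(=O)Nc1c(OC)cc(OC)cc1OC`, is not yet measured and carries methyl in place of hydrogen on a saturated chain carbon bound to a carbonyl carbon and two saturated chain carbons. This is the same kind of change as from compound 1 to compound 2, yet not the same: there the carbon was bound to an oxygen on an aromatic ring, here it is bound to a carbonyl carbon and two saturated chain carbons. Because the earlier step was a 1.3-fold lower number from compound 1 to compound 2 (0.12 log units; within the scatter), the expected step is a 1.2-fold lower number from compound 3 to compound 4 (0.08 log units; within the scatter), held loosely since the surroundings differ. For compound 4 the expected value in this assay is 30 nM, likely between 12 nM and 80 nM.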

Compound 4, half-maximal inhibitory concentration: 44 nM
Beside the measured number, compound 4's estimate is 1.5-fold (0.17 log units) below it; low and high end bracket the measured number.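

In this assay, methyl in place of hydrogen on the saturated chain carbon bound to a carbonyl carbon and two saturated chain carbons amounts to a 1.2-fold higher number from compound 3 to compound 4 (0.09 log units; within the scatter). Set beside the earlier step, the same kind of change reads alike on the two cores: the same change on two cores in this assay, a 1.3-fold lower number (0.12 log units; within the scatter) from compound 1 to compound 2 and a 1.2-fold higher number (0.09 log units; within the scatter) from compound 3 to compound 4, 1.6-fold (0.21 log units) apart, within the scatter of two such steps. This shows that neither step can be told apart from ordinary repeat variation, but it does not show that methyl would stay without effect on a further core, and the two steps rest on differently bound carbons.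

The compounds shown leave open what an ethyl group, a hydroxyl group or an amine would do on that same chain carbon.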